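This account rests on a few compounds, and the source may have more. Where it says the series, first, only, none or still open, it means among the compounds named here.

Working notes on the series in a functional assay on the whole organism (strain C57Bl/6) for inhibition, with Mus musculus as the target, with a stated time of 180 min, at 48 degrees C; a lower number here means that less compound is needed, a higher number that more compound is needed for the effect.

Compound 1 `COc1ccc(Cn2c(NCCNC(=N)N)nc(=O)n(Cc3ccc(Cl)cc3)c2=O)cc1` gives 0.004 nM and compound 2 `COc1ccc(Cn2c(=O)nc(NCCNC(=N)N)n(Cc3ccc(Cl)cc3)c2=O)cc1` gives 0.0044 nM; the two numbers lie within the scatter of each other, so no order between them is claimed. Within the data shown here, compound 3 `COc1ccc(Cn2c(=O)nc(NCCNC(=N)N)n(Cc3ccccc3)c2=O)cc1` gives 0.063 nM, the highest number among the three measured compounds: its nearest neighbour is compound 2, and the one measured step, a 14-fold higher number from compound 2 to compound 3 (1.16 log units; beyond the scatter), is the only step that bears on a substituent on this benzyl ring. It shows that removing the chloro costs much, beyond the scatter.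

Compound 4 `COc1ccc(Cn2c(NCCNC(=N)N)nc(=O)n(Cc3ccc(OC)cc3)c2=O)cc1` is the next compound to be measured. It differs from compound 3 by methoxy in place of hydrogen on an aromatic carbon. Among the measured compounds shown here, no measured step covers methoxy in this position; the chloro step is the only guide, and it says a group here rather than hydrogen gives a lower number. Whether methoxy matches chloro cannot be read from the data, so the step is expected to be downward, a 4.2-fold lower number from compound 3 to compound 4 (0.62 log units; beyond the scatter), but with a wide range. Compound 4 is therefore estimated at 0.015 nM, between 0.004 nM and 0.06 nM.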

Compound 4, half-maximal effective concentration: 0.000053 nM
Beside the measured number, compound 4's estimate is 280-fold (2.45 log units) above it; the whole stated range lies above it.
By their numbers in this assay, from the lowest: compound 4; then compounds 1 and 2 (each within the scatter of the next); then compound 3.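

In this assay, among these compounds, the earlier compounds compared only chloro with hydrogen on this benzyl group, and that step left open whether chloro was a high point; the change from benzyl to 4-methoxybenzyl gives a 1200-fold lower number from compound 3 to compound 4 (3.08 log units; beyond the scatter), and methoxy in place of chloro at the same position gives an 83-fold lower number from compound 2 to compound 4 (1.92 log units; beyond the scatter), so the order at this position, from the highest number to the lowest, is hydrogen, chloro, methoxy. The exchange of chloro for methoxy also lowers the number on the other benzyl group, with a 75-fold lower number from compound 1 to compound 4 (1.88 log units; beyond the scatter), so among the compounds shown, both changes from chloro to methoxy lead to the same compound with a 4-methoxybenzyl group on each side, and it has the lowest number of the four. Nothing available on this series gives a reason for the size of these steps.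

The compounds shown leave open whether the low number is specific to methoxy or extends to other groups at this position, such as hydroxyl, ethoxy, fluoro or a dimethylamino group. Among the compounds shown here, they also leave open how much the 4-methoxybenzyl group on each side contributes alone, since no compound here has plain benzyl on the other side, and whether the step holds with a longer chain in place of the ethyl link to the guanidine.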